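The source may hold more compounds than are shown below. What is called first, only, known or untested is meant among the compounds shown, and "the series" means these compounds.

Among the compounds with values here, in an ADME assay on L1210/0 cells (Mus musculus) for cytotoxicity, with a stated time of 48 h (on this read-out lower numbers stand for stronger inhibition and higher numbers for weaker inhibition), compound 1 (`O=c1[nH]c(=O)n([C@H]2C[C@H](O)[C@@H](CO)O2)cc1CO`) gives 9180 nM, while compound 2 (`[N-]=[N+]=NCc1cn([C@H]2C[C@H](O)[C@@H](CO)O2)c(=O)[nH]c1=O`) gives 124000 nM, the higher of the two numbers so far. The account now turns to compound 3 (`O=c1[nH]c(=O)n([C@H]2C[C@H](O)[C@@H](CO)O2)cc1C#CCO`), which has 3-hydroxyprop-1-yn-1-yl in place of azidomethyl on an aromatic carbon. Within the data shown here, only one measured step bears on this change. It is a 14-fold higher number from compound 1 to compound 2 (1.13 log units; beyond the scatter), a large step beyond the scatter, made by putting azido in place of hydroxy on a saturated chain carbon bound to an aromatic carbon. The new change also removes the azido group and restores a hydroxy group, but on a 3-hydroxyprop-1-yn-1-yl group rather than on the short chain of compound 1, so that step is only a partial guide. A move back towards lower numbers in this assay is therefore expected, though probably not the full size of the measured step. The expected change is a 4.1-fold lower number from compound 2 to compound 3 (0.62 log units; beyond the scatter), which would be a moderate step. For compound 3 the estimated value is 30000 nM, with an expected range from 5000 nM to 180000 nM.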

Compound 3, half-maximal inhibitory concentration: > 200000 nM
Compound 3 gave a limit, no number (the forecaster's own chance of this, stated with the estimate: 15%); at least 6.6-fold (0.82 log units) between middle value and limit.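

In this assay compound 3 gives no number, only a limit of the assay: the limit of > 200000 nM in this assay, at which 1 of the 3 values shown sits. Read against the azidomethyl compound, this is an at least 1.6-fold higher number from compound 2 to compound 3 (0.20 log units; that floor lies within the scatter), so the hydroxy group at the end of 3-hydroxyprop-1-yn-1-yl brought no return to lower numbers, and how far the two compounds really lie apart cannot be told. Read against the hydroxymethyl compound, it is an at least 21-fold higher number from compound 1 to compound 3 (1.33 log units; beyond the scatter), which shows what the earlier pair could not: on this aromatic carbon, two atoms from the ring nitrogen, the presence of a hydroxy group does not by itself preserve the number of compound 1, and the group that carries it matters as well.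

The compounds shown do not separate the triple bond of 3-hydroxyprop-1-yn-1-yl from the length of its chain, and a saturated 3-hydroxypropyl group on the same carbon would be needed to tell the two apart. They also leave open how the shared core behaves with an aminomethyl group or a carboxylic acid at this position.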